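Expected Cell Tolerance after a Bromomethylphenyl Swap

The source may report more compounds than this note shows. Statements on the series, on what has been measured and on what is new or still open speak of the compounds shown alone.

Of the compounds shown here, two of a small series have been tested in an ADME assay on MT4 cells (Homo sapiens) for cytotoxicity, read by MTT assay; a lower number here means that less compound is tolerated, a higher number that more compound is tolerated. Compound 1, `Cc1ccc(N(C(=O)c2cccc(C)c2)C(=S)OCCN2C(=O)c3ccccc3C2=O)cc1`, gave only a limit in this assay, > 100000 nM, so no number is known for it. One of the two readings is therefore (the limit of > 100000 nM in this assay, at which 1 of the 2 values shown sits), and it belongs to compound 1. Compound 2, `O=C1c2ccccc2C(=O)N1CCOC(=S)N(C(=O)c1cccc(F)c1F)c1ccc(Cl)cc1`, gave a number in this assay, 58000 nM. Among the values shown, compound 2 thus holds the only number, and the other reading is a limit.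

Compound 3, `Cc1cc(C(=O)N(C(=S)OCCN2C(=O)c3ccccc3C2=O)c2ccc(Cl)cc2)ccc1Br`, has not been measured yet. It differs from compound 2 in a single respect:

4-bromo-3-methylphenyl in place of 2,3-difluorophenyl on a carbonyl carbon

Among the measured compounds shown here, no pair of measured compounds differing in one place is available, so the effect of such a swap on how much compound the cells tolerate cannot be read from these data. The expectation is that the step of a 1.3-fold lower number from compound 2 to compound 3 (0.11 log units; within the scatter) is small, no larger than the usual scatter of this assay. Compound 3 is accordingly expected to come out near 45000 nM, with a range from 15000 nM to 130000 nM.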

Compound 3, half-maximal cytotoxic concentration: 18000 nM
For compound 3 the middle estimate is 2.5-fold (0.40 log units) above the measured one; measured number inside the range.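

In this assay, putting 4-bromo-3-methylphenyl in place of 2,3-difluorophenyl on a carbonyl carbon gives a 3.2-fold lower number from compound 2 to compound 3 (0.51 log units; beyond the scatter), so the cells tolerate less of the compound after this swap. Among the compounds shown here, this is the first comparison between two compounds that differ in only one place, and it shows that the group on this carbonyl carbon can change the reading by more than the usual scatter, even though the two groups match in heavy-atom count, each has one aromatic ring, and neither carries a net charge. Nothing measured here gives a reason for the step.

The compounds shown leave open which part of the swap carries the step, whether the bromine, the methyl or the loss of the two fluorines, and how a plain phenyl, or a ring bearing an amine or a carboxylic acid, would read in this assay. Compound 1 stands only as a limit, > 100000 nM, and its steps to the other compounds cannot be read.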